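The source may hold more compounds than are shown below. What is called first, only, known or untested is meant among the compounds shown, and "the series" means these compounds.

Values from a functional assay on MCF7 cells (Homo sapiens) for inhibition, read by MTT assay, with a stated time of 48 h (a lower number here means a stronger inhibitor, a higher number a weaker inhibitor), are these:
- compound 1 `COc1cc(C2SCC(=O)N2NC(=O)COc2ccc3c(-c4ccccc4)cc(=O)oc3c2)cc(OC)c1OC` gives 21.2 ug/mL
- compound 2 `CCn1c(C)cs/c1=N\NC(=O)COc1ccc2c(-c3ccccc3)cc(=O)oc2c1` gives 78 ug/mL
- compound 3 `CC(=O)c1s/c(=N\NC(=O)COc2ccc3c(-c4ccccc4)cc(=O)oc3c2)n(C)c1C` gives 42 ug/mL

In this assay compound 3 lies within the usual scatter of both compound 1 and compound 2, so it holds no clear rank among the three. Compound 4 `CCn1c(C)c(C(C)=O)s/c1=N\NC(=O)COc1ccc2c(-c3ccccc3)cc(=O)oc2c1` differs from compound 3 by methyl in place of hydrogen on a saturated chain carbon bound to an aromatic nitrogen and this reads as methyl in place of hydrogen on a saturated chain carbon bound to an aromatic nitrogen, or methyl to ethyl. Within the data shown here, the only measured step touching this group is a 1.9-fold lower number from compound 2 to compound 3 (0.27 log units; within the scatter) and it changes more than this one place, yet it stays within the scatter, so no step beyond the scatter is expected in either direction. The expected 1.2-fold higher number from compound 3 to compound 4 (0.08 log units; within the scatter) is a small one, within the scatter. For compound 4 the estimated value is 50 ug/mL with an expected range from 25 ug/mL to 100 ug/mL.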

Compound 4, half-maximal inhibitory concentration: 28 ug/mL
Beside the measured number, compound 4's estimate is 1.8-fold (0.25 log units) above it, within the range that was stated.
By their numbers in this assay, from the lowest: compounds 1, 4, 3 and 2 (each within the scatter of the next, the first and the last beyond it).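

In this assay, methyl in place of hydrogen on a saturated chain carbon bound to an aromatic nitrogen, the change from methyl to ethyl, gives a 1.5-fold lower number from compound 3 to compound 4 (0.18 log units; within the scatter), so the two compounds cannot be told apart and this place accepts ethyl without a clear change. Among these compounds, with ethyl held fixed, acetyl in place of hydrogen on an aromatic carbon gives a 2.8-fold lower number from compound 2 to compound 4 (0.44 log units; beyond the scatter), a modest step that is the first one here beyond the scatter. Nothing available explains either step. On these data alone, how a propyl chain at the first place, or a carboxylic acid or an amine in place of the acetyl, would read remains open.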